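Aryl-ether variation on a shared triazole amide core

The compounds below may be only part of what the source reports. "The series", "measured", "known", "first", "only" and "open" are said of these compounds alone.

Measured: compound 1 `Cc1cccc(OCC(=O)Nc2nc(-c3ccccc3)n[nH]2)c1` gives 1500 nM; compound 2 `O=C(COc1ccccc1)Nc1nc(-c2ccccc2)n[nH]1` gives 2300 nM; compound 3 `Cc1cc(C)cc(OCC(=O)Nc2nc(-c3ccccc3)n[nH]2)c1` gives 2700 nM, all in an assay on CHO cells for displacement of a labelled ligand from adenosine receptor A3 (Homo sapiens), read by scintillation counting, with a stated time of 60 min; on this read-out lower numbers stand for stronger inhibition and higher numbers for weaker inhibition.

On these numbers compound 3 is not set apart: a 1.2-fold higher number from compound 2 to compound 3 (0.07 log units; within the scatter) and a 1.8-fold higher number from compound 1 to compound 3 (0.26 log units; within the scatter) both lie within the scatter, as does a 1.5-fold higher number from compound 1 to compound 2 (0.19 log units; within the scatter).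

Compound 4 `O=C(COCc1ccccc1)Nc1nc(-c2ccccc2)n[nH]1` carries benzyl in place of 3,5-dimethylphenyl on an oxygen on a saturated carbon. The nearest measured step is a 1.2-fold higher number from compound 2 to compound 3 (0.07 log units; within the scatter), which swaps groups at the same oxygen and showed nothing beyond the scatter; the methyl steps a 1.5-fold higher number from compound 1 to compound 2 (0.19 log units; within the scatter) and a 1.8-fold higher number from compound 1 to compound 3 (0.26 log units; within the scatter) were likewise flat. Within the data shown here, no measured step replaces an aromatic ring on the oxygen by benzyl, so the range is kept wide. For compound 4 the expected step is a 1.1-fold lower number from compound 3 to compound 4 (0.03 log units; within the scatter), with an estimate of 2500 nM, range 800 nM to 8000 nM.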

Compound 4, inhibition constant: 4600 nM
Beside the measured number, compound 4's estimate is 1.8-fold (0.26 log units) below it, and the stated range covers the measured number.
By their numbers in this assay, from the lowest: compounds 1, 2, 3 and 4 (each within the scatter of the next, the first and the last beyond it).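

Benzyl on the oxygen gives the first step beyond the scatter in this set: in this assay there is a 3.1-fold higher number from compound 1 to compound 4 (0.49 log units; beyond the scatter) with benzyl in place of 3-methylphenyl. This modest separation does not extend to the other two aryl ethers: there is a 2.0-fold higher number from compound 2 to compound 4 (0.30 log units; within the scatter) and also a 1.7-fold higher number from compound 3 to compound 4 (0.23 log units; within the scatter) with both inside the scatter. Nothing available explains this step.

Still open, from the compounds shown here alone, is whether a longer chain on the oxygen, or an amine or a carboxylic acid on the benzyl ring, would separate the number from all three aryl ethers.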